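Trimming an Ester Chain on a Glycolipid Core

A few compounds are considered here, and "the series" means these few. Any claim that something is new, unique, unknown or untested is made for them only; others in the source may bear on it.

Two glycolipids have been measured. In a functional assay on NCI-H460 cells (Homo sapiens) for antiproliferative activity, read by MTT assay, with a stated time of 48 h (on this read-out higher numbers stand for weaker inhibition and lower numbers for stronger inhibition), compound 1 `CCCCCCCCCCCCO[C@@H]1O[C@@H](C)[C@H](O[C@@H]2O[C@@H](C)[C@H](OC(C)=O)[C@@H](O[C@@H]3O[C@@H](C)[C@H](O)[C@@H](OC(C)=O)[C@H]3OC(C)=O)[C@H]2O)[C@@H](O)[C@H]1O` gives 13000 nM, while compound 2 `CCCCCCCCO[C@@H]1O[C@@H](C)[C@H](OC(=O)CCCCC)[C@@H](O[C@@H]2O[C@@H](C)[C@H](OC(C)=O)[C@@H](OC(=O)CCC)[C@H]2OC(C)=O)[C@H]1O` gives 32000 nM, the higher of the two numbers and beyond the scatter from compound 1. Compound 3 `CCCCCCCCO[C@@H]1O[C@@H](C)[C@H](OC(=O)CCCCC)[C@@H](O[C@@H]2O[C@@H](C)[C@H](OC(C)=O)[C@@H](OC(C)=O)[C@H]2OC(C)=O)[C@H]1O` differs from compound 2 only by hydrogen in place of ethyl on a saturated chain carbon bound to a carbonyl carbon. Among the compounds with values here, no two measured compounds differ in a single place, so no step of this kind is known; the change is expected to be small, with a 1.3-fold lower number from compound 2 to compound 3 (0.11 log units; within the scatter) falling within the scatter. Compound 3 is therefore estimated at 25000 nM, with a range from 10000 nM to 60000 nM.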

Compound 3, half-maximal inhibitory concentration: 15000 nM
For compound 3 the middle estimate is 1.7-fold (0.22 log units) above the measured one; low and high end bracket the measured number.
By their numbers in this assay, from the lowest: compounds 1 and 3 (each within the scatter of the next); then compound 2.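

In this assay, within the data shown here, the first comparison that changes a single place gives a 2.1-fold lower number from compound 2 to compound 3 (0.33 log units; beyond the scatter) and so shows that this position is not silent. Replacing the propylcarbonyl ester with acetyl on an otherwise identical structure brings a modest gain in inhibition. Nothing available explains this gain. Going by these compounds, whether the number would keep moving in the same direction with a free hydroxyl at this place remains open. A single step also cannot show what a longer chain or an amine here would do.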